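Bromo to methoxy on two related cores

This account rests on a few compounds, and the source may have more. Where it says the series, first, only, none or still open, it means among the compounds named here.

Measured in a functional assay on WiDr cells (Homo sapiens) for inhibition, read by sulforhodamine B assay, with a stated time of 48 h; a lower number here means a stronger inhibitor of growth, a higher number a weaker inhibitor of growth:
compound 1 `COC(=O)[C@@]1(C)CCC=C2[C@@H]1CC[C@@H](C)[C@]2(C)Cc1c(C)[nH]c2ccc(Br)cc12` gives 15000 nM
compound 2 `COC(=O)[C@@]1(C)CCC=C2[C@@H]1CC[C@@H](C)[C@]2(C)Cc1c(C)[nH]c2ccc(OC)cc12` gives 17000 nM
compound 3 `COC(=O)[C@@]1(C)CC[C@@H]2C3=C1CC[C@@H](C)[C@]3(C)Cc1c2[nH]c2ccc(Br)cc12` gives 22000 nM

Compound 2 is compound 1 with methoxy in place of bromo on an aromatic carbon; the step is a 1.1-fold higher number from compound 1 to compound 2 (0.05 log units; within the scatter). Compound 3 carries a different core; the difference between the two cores is not broken down here. Its value and those of compound 1 and compound 2 fall within the scatter of one another.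

Compound 4 `COC(=O)[C@@]1(C)CC[C@@H]2C3=C1CC[C@@H](C)[C@]3(C)Cc1c2[nH]c2ccc(OC)cc12` is compound 3 with methoxy in place of bromo on an aromatic carbon. The place differs from the earlier pair in being part of a fused or bridged system of five rings rather than two, so this is the same kind of change, not the same one.

For compound 4 the step of a 1.1-fold higher number from compound 3 to compound 4 (0.04 log units; within the scatter) is expected to sit beside a 1.1-fold higher number from compound 1 to compound 2 (0.05 log units; within the scatter), because compound 3 gives 22000 nM and the earlier swap moved little. Compound 4 is estimated at 24000 nM, between 12000 nM and 48000 nM.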

Compound 4, concentration for 50% growth inhibition: 1200 nM
The estimate for compound 4 lay 20-fold (1.30 log units) above the measured number, and the stated range ends above it.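

In this assay, methoxy in place of bromo on an aromatic carbon gives an 18-fold lower number from compound 3 to compound 4 (1.26 log units; beyond the scatter), and the two cores do not respond alike to this swap: the same change on two cores in this assay, a 1.1-fold higher number (0.05 log units; within the scatter) from compound 1 to compound 2 and an 18-fold lower number (1.26 log units; beyond the scatter) from compound 3 to compound 4, 21-fold (1.32 log units) apart, beyond the scatter of two such steps

A step read on one core is therefore a poor guide to the same change on the other, at least for these two pairs. The pairs do not show which difference between the cores accounts for the gap, or whether the gain comes from methoxy entering or bromo leaving.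

Still open, as far as these compounds go, is whether hydroxy, chloro or an amine at this place on the core of compound 3 would track methoxy or bromo. Also open, from the compounds shown here alone, is whether compound 4 would hold its level with a carboxylic acid in place of the ester.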